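Methoxy for chloro on the aryl piperazine, dose expected

The source may hold more compounds than are shown below. What is called first, only, known or untested is meant among the compounds shown, and "the series" means these compounds.

The shared core carries a phenylpiperazine amide, and the ring on the piperazine nitrogen varies. Compound 1 `CC1(c2ccccc2)CC(=O)N(CC(=O)N2CCN(c3ccccc3F)CC2)C1=O` gives 100 mg/kg in a functional assay on the whole organism (strain CD-1) with Mus musculus as the target, with a stated time of 0.5 h; a lower number here means that less compound is needed, a higher number that more compound is needed for the effect. Compound 2 `CC1(c2ccccc2)CC(=O)N(CC(=O)N2CCN(c3ccc(Cl)cc3)CC2)C1=O` gives 300 mg/kg, and the step of a 3.0-fold higher number from compound 1 to compound 2 (0.48 log units; beyond the scatter) shows the change. Compound 3 `CC1(c2ccccc2)CC(=O)N(CC(=O)N2CCN(c3ccccc3Cl)CC2)C1=O` is reported in this assay as "not active" (no number reported), so no number places it against the other two; it stands apart only in that no effective dose was found. Compound 4 `COc1ccccc1N1CCN(C(=O)CN2C(=O)CC(C)(c3ccccc3)C2=O)CC1` differs from compound 3 by methoxy in place of chloro on an aromatic carbon, that is, 2-chlorophenyl becomes 2-methoxyphenyl, on an aromatic carbon ortho to a large group. Within the data shown here, no measured step covers this change; the only step in hand, from compound 1 to compound 2, concerns a different position and was modest. With compound 3 giving no number, the expectation for compound 4 rests on compound 1 and compound 2 alone, and a dose near theirs is expected, with wide uncertainty. Compound 4 is estimated at 300 mg/kg, between 100 mg/kg and 1000 mg/kg.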

Compound 4, minimum effective dose: "not active" (no number reported)
Compound 4: no number reported, and the estimate cannot be compared.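

In this assay compound 3 and compound 4 are both reported without a number, so no step can be read between them. Nothing measured here offers an explanation for either result. The compounds shown leave open how 2-chlorophenyl and 2-methoxyphenyl compare on the shared core.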